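A few compounds are considered here, and "the series" means these few. Any claim that something is new, unique, unknown or untested is made for them only; others in the source may bear on it.

In a functional assay on B16-F10 cells (Mus musculus) for antiproliferative activity, read by ELISA and MTT assay, with a stated time of 48 h (a lower number here means a stronger inhibitor, a higher number a weaker inhibitor), compound 1 `O=C(/C=C/c1ccccc1)NS(=O)(=O)c1ccc(F)cc1` gives 2.1 ug/mL, compound 2 `O=C(/C=C/c1ccc(Cl)cc1)NS(=O)(=O)c1ccc(F)cc1` gives 2 ug/mL, and compound 3 `COc1ccc(/C=C/C(=O)NS(=O)(=O)c2ccc(F)cc2)cc1` gives 5.1 ug/mL, the highest of the three numbers. The chloro step a 1.1-fold lower number from compound 1 to compound 2 (0.02 log units; within the scatter) stays within the scatter, whereas the methoxy steps a 2.4-fold higher number from compound 1 to compound 3 (0.39 log units; beyond the scatter) and a 2.6-fold higher number from compound 2 to compound 3 (0.41 log units; beyond the scatter) are modest rises. Compound 4 `CN(C)c1ccc(/C=C/C(=O)NS(=O)(=O)c2ccc(F)cc2)cc1` differs from compound 3 by dimethylamino in place of methoxy on an aromatic carbon. Going by the values given here, no measured step exchanges one para acceptor for another, so only the two methoxy steps bear on this change, and they give no direction for it; a step within the scatter, or a small one either way, is expected. Compound 4 is therefore expected to show a 1.1-fold higher number from compound 3 to compound 4 (0.03 log units; within the scatter). Compound 4 is estimated at 5.5 ug/mL, within a range from 2.5 ug/mL to 12 ug/mL.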

Compound 4, half-maximal inhibitory concentration: 2.3 ug/mL
For compound 4 the middle estimate is 2.4-fold (0.38 log units) above the measured one, outside the stated range (below it).
By their numbers in this assay, from the lowest: compounds 2, 1 and 4 (each within the scatter of the next); then compound 3.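

At this place, para to a large group, a 2.2-fold lower number from compound 3 to compound 4 (0.35 log units; beyond the scatter) separates dimethylamino from methoxy, although each group counts one hydrogen-bond acceptor. With a 1.2-fold higher number from compound 2 to compound 4 (0.06 log units; within the scatter) and a 1.1-fold higher number from compound 1 to compound 4 (0.04 log units; within the scatter) both within the scatter, hydrogen, chloro and dimethylamino give matching numbers here, and methoxy in compound 3 is the lone exception. No measurement at hand gives a reason for this. Open, going by these compounds, is whether ethoxy follows methoxy, and whether a primary amine or a carboxylic acid at this place stays level with compound 4.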